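Pendant aryl swap, compound 3 to compound 4

The source may report more compounds than this note shows. Statements on the series, on what has been measured and on what is new or still open speak of the compounds shown alone.

Compound 1 `Cc1cc(C)cc(-c2cc(C)c(Nc3ccnc(Nc4ccc(C#N)cc4)n3)c(C)c2)c1`, compound 2 `Cc1cc(-c2cc(Cl)cc(Cl)c2)cc(C)c1Nc1ccnc(Nc2ccc(C#N)cc2)n1` and compound 3 `Cc1cc(-c2ccc(Cl)cc2)cc(C)c1Nc1ccnc(Nc2ccc(C#N)cc2)n1` share one core and differ only in the pendant aryl. In an ADME assay on MT4 cells (Homo sapiens) for cytotoxicity, read by MTT assay, with a stated time of 4 days (a higher number here means that more compound is tolerated, a lower number that less compound is tolerated), compound 1 gives 4140 nM, compound 2 gives 4290 nM and compound 3 gives 4190 nM. The steps of a 1.0-fold higher number from compound 1 to compound 2 (0.02 log units; within the scatter), a 1.0-fold higher number from compound 1 to compound 3 (0.01 log units; within the scatter) and a 1.0-fold lower number from compound 2 to compound 3 (0.01 log units; within the scatter) all stay within the scatter. Compound 3 stands second highest of the three numbers, nearest to compound 1, furthest from compound 2, both gaps within the scatter. Compound 4 `Cc1cc(-c2cccc(Cl)c2)cc(C)c1Nc1ccnc(Nc2ccc(C#N)cc2)n1` differs from compound 3 by 3-chlorophenyl in place of 4-chlorophenyl on an aromatic carbon. All three measured steps bear on this change, each swapping one pendant aryl for another at the same place, and none moved the number beyond the scatter. A step of a 1.0-fold higher number from compound 3 to compound 4 (0.00 log units; within the scatter) is therefore expected, nothing beyond the scatter in either direction. Compound 4 is estimated at 4200 nM, range 2100 nM to 8400 nM.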

Compound 4, half-maximal cytotoxic concentration: 2160 nM
Estimate against measurement, compound 4: 1.9-fold (0.29 log units) above; measured number inside the range.
By their numbers in this assay, from the lowest: compounds 4, 1, 3 and 2 (each within the scatter of the next).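

In this assay, 3-chlorophenyl in place of 4-chlorophenyl gives a 1.9-fold lower number from compound 3 to compound 4 (0.29 log units; within the scatter), loss of one chloro from the 3,5-dichlorophenyl gives a 2.0-fold lower number from compound 2 to compound 4 (0.30 log units; within the scatter), and 3-chlorophenyl in place of 3,5-dimethylphenyl gives a 1.9-fold lower number from compound 1 to compound 4 (0.28 log units; within the scatter). All three stay within the scatter, so the place of the chloro on the pendant ring is not shown to matter here, even though these steps are larger than the earlier ones. Nothing available accounts for these steps. On these data alone, whether a pendant aryl carrying an amine or a carboxylic acid would go beyond the scatter remains open.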